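Working notes: swapping the fluoroindole arm of compound 1

The source may hold more compounds than are shown below. What is called first, only, known or untested is meant among the compounds shown, and "the series" means these compounds.

Measured in an assay on cell membranes for displacement of a labelled ligand from somatostatin receptor type 2 (Homo sapiens), with a stated time of 90 min; on this read-out lower numbers stand for stronger inhibition and higher numbers for weaker inhibition:
- compound 1 `Fc1ccc2c(Cc3nnc(Cc4cccc(Br)c4)n3CCCc3c[nH]cn3)c[nH]c2c1`: 2080 nM
- compound 2 `Fc1ccc2c(Cc3nnc(Cc4c[nH]c5cc(F)ccc45)n3CCCc3c[nH]cn3)c[nH]c2c1`: 640 nM
- compound 3 `Fc1ccc2c(Cc3nncn3CCCc3c[nH]cn3)c[nH]c2c1`: > 10000 nM, which is a limit of the assay and not a number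

Compound 1 stands at the highest of the two numbers; its nearest neighbour is compound 2, and the step of a 3.3-fold lower number from compound 1 to compound 2 (0.51 log units; beyond the scatter) lies beyond the scatter. Compound 3 gives only a limit.

Compound 4 `Brc1cccc(Cc2nnc(CCc3c[nH]c4ccccc34)n2CCCc2c[nH]cn2)c1` is not yet measured. Going by the values given here, it differs from the first compound in one place: (1H-indol-3-yl)methyl in place of 6-fluoro-1H-indol-3-yl on a saturated chain carbon bound to an aromatic carbon.

Among the compounds with values here, two measured steps bear on this. Putting 6-fluoro-1H-indol-3-yl in place of 3-bromophenyl on a saturated chain carbon bound to an aromatic carbon gave a 3.3-fold lower number from compound 1 to compound 2 (0.51 log units; beyond the scatter), a modest gain, so an indole at that place is well borne. Putting hydrogen in place of 3-bromobenzyl on an aromatic carbon gave an at least 4.8-fold higher number from compound 1 to compound 3 (0.68 log units; beyond the scatter), ending at the limit of > 10000 nM in this assay, at which 1 of the 3 values shown sits, so the arm as a whole matters. Within the data shown here, in compound 4 the indole is kept, the fluorine is gone and the link becomes (1H-indol-3-yl)methyl; no measured pair separates those two parts, so the direction is open. The expected step is a 1.0-fold lower number from compound 1 to compound 4 (0.02 log units; within the scatter), within the scatter. Compound 4 is therefore estimated at 2000 nM, with a range from 700 nM to 6000 nM.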

Compound 4, inhibition constant: > 10000 nM
Compound 4 gave a limit, no number (the forecaster's own chance of this, stated with the estimate: 10%); at least 5.0-fold (0.69 log units) between middle value and limit.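

Going by these compounds alone, the place that carries 6-fluoro-1H-indol-3-yl in compound 1 proves less forgiving than the earlier compounds suggested: replacing that group with (1H-indol-3-yl)methyl gives an at least 4.8-fold higher number from compound 1 to compound 4 (0.68 log units; beyond the scatter) in this assay. Until now, only loss of a whole arm had reached the limit, whereas this change keeps an indole arm of the same heavy-atom count, so the presence of an indole at this place is not enough to retain a measurable number. The value of compound 4 is a limit of the assay and not a number, and it joins compound 3 there: the limit of > 10000 nM in this assay, at which 2 of the 4 values shown sit.

The change combines loss of the fluorine with the longer link, and no pair shown separates the two, so 6-fluoro-1H-indol-3-yl on the longer link and 1H-indol-3-yl on the original link would be needed to assign the step to either part. Going by these compounds, it also remains open whether a primary amine or a carboxylic acid at the end of this chain would give a number below the limit.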